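The source may hold more compounds than are shown below. What is called first, only, known or untested is meant among the compounds shown, and "the series" means these compounds.

Among the compounds with values here, compound 2 `COC(=O)c1ccc(NCc2cncn2Cc2ccccc2N)cc1-c1ccccc1` is, in a toxicity assay on NIH3T3 cells (Mus musculus) for cytotoxicity, read by resazurin assay (a higher number here means that more compound is needed for the effect, a lower number that less compound is needed), the one compound with an actual number: compound 2 gives 25000 nM. Compound 1 `Nc1cc(-c2ccccc2)ccc1Cn1cncc1CNc1ccc(-c2cncs2)c(-c2ccccc2)c1` reaches only a limit of the assay, > 1000 nM. Compound 3 `COc1ccc(NCc2cncn2Cc2ccc(-c3ccccc3)cc2N)cc1-c1ccccc1` likewise stops at a limit, > 1000 nM. The step that the two limits leave unreadable from compound 1 to compound 3 therefore cannot be read, and the limit of > 1000 nM in this assay, at which 2 of the 3 values shown sit, is all that these two compounds share. Compound 4 `COC(=O)c1ccc(NCc2cncn2Cc2cccc(Br)c2)cc1-c1ccccc1` differs from compound 2 by 3-bromophenyl in place of 2-aminophenyl on a saturated chain carbon bound to an aromatic nitrogen. Within the data shown here, no measured step touches this change, so there is no ground for expecting a shift beyond the scatter in this assay. Compound 4 is therefore estimated at 25000 nM, with a range from 8000 nM to 80000 nM. The expected step of no change at the digits printed from compound 2 to compound 4 (within the scatter) is thus close to none.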

Compound 4, half-maximal effective concentration: > 10000 nM
Compound 4 gave a limit, no number (the forecaster's own chance of this, stated with the estimate: 30%); the middle value does not contradict the limit.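

In this assay compound 4 stops at a limit, > 10000 nM, so no step can be read from compound 2 to compound 4. The compounds shown leave open whether 3-bromophenyl in place of 2-aminophenyl changes the value at all.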